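Removing the amine substituent of a weak acetylcholine receptor antagonist

The source may hold more compounds than are shown below. What is called first, only, known or untested is meant among the compounds shown, and "the series" means these compounds.

Compound 1 `c1ccc(CCCN2CCCC(COCc3ccccc3-c3ccccc3)C2)cc1` is the weaker of two measured compounds: in an in vitro functional assay on HEK ts201 cells for antagonist activity at Neuronal acetylcholine receptor; alpha4/beta2 (Homo sapiens), read by fluorescence and calcium flux (on this read-out higher numbers stand for weaker inhibition and lower numbers for stronger inhibition), compound 1 gives 12600 nM, while compound 2 `CC1CC(=O)N(c2ccccc2C(=O)OCC2CCCN(CCCCOc3ccccc3)C2)C1=O` gives 1700 nM, a gap that exceeds the usual scatter. Compound 3 `c1ccc(-c2ccccc2COCC2CCCNC2)cc1` shares the core of compound 1 but carries hydrogen in place of 3-phenylpropyl on an amine nitrogen in a ring, a hydrogen in place of 3-phenylpropyl on an amine nitrogen in a ring. Among the measured compounds shown here, no measured pair shows this kind of change, so its size is unknown. Because compound 1 already sits at 12600 nM, the step from compound 1 to compound 3 is expected to be a 2.4-fold higher number from compound 1 to compound 3 (0.38 log units; beyond the scatter), towards weaker inhibition. Compound 3 is estimated at 30000 nM, within 8000 nM to 100000 nM.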

Compound 3, half-maximal inhibitory concentration: 4170 nM
Compound 3: the middle estimate sits 7.2-fold (0.86 log units) above what was measured, and the stated range ends above it.
By their numbers in this assay, from the lowest: compound 2; then compound 3; then compound 1.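

Taking the 3-phenylpropyl off the amine nitrogen in the ring gives, in this assay, a 3.0-fold lower number from compound 1 to compound 3 (0.48 log units; beyond the scatter), a modest step towards stronger inhibition. So on the core of compound 1, this large group is not needed for the inhibition seen, and the plain hydrogen does better. Nothing at hand explains this gain. As far as these compounds go, it remains open whether a methyl or a benzyl on that nitrogen would keep the gain. From the compounds shown here alone, it also remains open whether the chain or its aromatic ring accounts for the weaker inhibition of compound 1.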